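The source may hold more compounds than are shown below. What is called first, only, known or untested is meant among the compounds shown, and "the series" means these compounds.

Measured so far:
- Compound 1 `CN(C)c1ccc(C=C2C(=O)N(c3ccc(Cl)cc3)N(c3ccc(Cl)cc3)C2=O)cc1`: > 128000 nM
- Compound 2 `O=C1C(=Cc2ccc(Cl)cc2)C(=O)N(c2ccc(Cl)cc2)N1c1ccc(Cl)cc1`: 30900 nM
- Compound 3 `COc1ccccc1C=C1C(=O)N(c2ccc(Cl)cc2)N(c2ccc(Cl)cc2)C1=O`: 25800 nM

Among the compounds with values here, in a functional assay on SMMC-7721 cells (Homo sapiens) for cytotoxicity, read by MTT assay, with a stated time of 72 h (a lower number here means a stronger inhibitor, a higher number a weaker inhibitor), compound 3 gives 25800 nM, and the only other exact number lies close to it, with a 1.2-fold lower number from compound 2 to compound 3 (0.08 log units; within the scatter). The entry for compound 1 is a limit, not a number.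

Compound 4 `O=C1C(=Cc2ccc(Cl)cc2Cl)C(=O)N(c2ccc(Cl)cc2)N1c1ccc(Cl)cc1` carries 2,4-dichlorophenyl in place of 2-methoxyphenyl on a double-bonded chain carbon bound to a double-bonded ring carbon.

Within the data shown here, the nearest precedent is the exchange at this same place between compounds 2 and 3, a 1.2-fold lower number from compound 2 to compound 3 (0.08 log units; within the scatter). The larger steps, an at least 4.1-fold lower number from compound 1 to compound 2 (0.61 log units; beyond the scatter) and an at least 4.9-fold lower number from compound 1 to compound 3 (0.69 log units; beyond the scatter), both start from the 4-(dimethylamino)phenyl of compound 1, a group absent here. No step beyond the scatter is therefore expected in this assay. The expected step is a 1.1-fold lower number from compound 3 to compound 4 (0.03 log units; within the scatter). For compound 4 the estimated value is 24000 nM, with an expected range from 9000 nM to 70000 nM.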

Compound 4, half-maximal inhibitory concentration: > 128000 nM
Compound 4 gave a limit, no number; the forecaster's own chance of this, stated with the estimate: 10%; middle value at least 5.3-fold (0.72 log units) away from the limit.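

In this assay, exchanging the group on the double-bonded chain carbon can matter even without the 4-(dimethylamino)phenyl of compound 1, with an at least 4.9-fold higher number from compound 3 to compound 4 (0.69 log units; beyond the scatter). A single chloro in place of hydrogen on an aromatic carbon is enough, with an at least 4.1-fold higher number from compound 2 to compound 4 (0.61 log units; beyond the scatter). Compound 4 shares a limit, not a number, with compound 1, so the step between them cannot be read: the limit of > 128000 nM in this assay, at which 2 of the 4 values shown sit. Still open, as far as these compounds go, is how a phenyl ring carrying a hydroxyl or an amine would read at this place, and whether any group here gives a number clearly lower than those of compound 2 and compound 3.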